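This account rests on a few compounds, and the source may have more. Where it says the series, first, only, none or still open, it means among the compounds named here.

Three compounds have been measured in an assay on CHO-K1 cells for antagonist activity at transient receptor potential cation channel subfamily V member 1 (Homo sapiens), read by FLIPR; on this read-out lower numbers stand for stronger inhibition and higher numbers for weaker inhibition:

compound 1, `CCCCCSc1nc(C(F)(F)F)ccc1CNC(=O)C(C)c1ccc(NS(C)(=O)=O)c(F)c1`, gives 95.6 nM
compound 2, `CC(C)CCSc1nc(C(F)(F)F)ccc1CNC(=O)C(C)c1ccc(NS(C)(=O)=O)c(F)c1`, gives 82 nM
compound 3, `CC1CCN(CCCSc2nc(C(F)(F)F)ccc2CNC(=O)C(C)c2ccc(NS(C)(=O)=O)c(F)c2)CC1`, gives 217 nM

Compound 3 stands highest of the three numbers, that is, it is the weakest inhibitor among them. The step from compound 1 to compound 3 was a 2.3-fold higher number from compound 1 to compound 3 (0.36 log units; beyond the scatter), and the step from compound 2 to compound 3 was a 2.6-fold higher number from compound 2 to compound 3 (0.42 log units; beyond the scatter), while compound 1 and compound 2 themselves differ by a 1.2-fold lower number from compound 1 to compound 2 (0.07 log units; within the scatter).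

Compound 4, `CC1CCC(Sc2nc(C(F)(F)F)ccc2CNC(=O)C(C)c2ccc(NS(C)(=O)=O)c(F)c2)CC1`, has not yet been measured. The change from compound 3 is 4-methylcyclohexyl in place of 3-(4-methylpiperidin-1-yl)propyl on a sulfur. The two measured steps that bear on it are those that brought the piperidine-containing chain in: both raised the number by a modest amount. Compound 4 takes that ring with its nitrogen out again and puts a carbon-only ring directly on the sulfur. Among the compounds with values here, no measured step shows a ring attached straight to the sulfur, so the expectation rests on reversing the two modest steps. In this assay compound 4 is therefore expected to give 110 nM, within a range of 45 nM to 300 nM. This estimate means an expected step of a 2.0-fold lower number from compound 3 to compound 4 (0.30 log units; within the scatter).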

Compound 4, half-maximal inhibitory concentration: 180 nM
Compound 4: the middle estimate sits 1.6-fold (0.21 log units) below what was measured, within the range that was stated.
By their numbers in this assay, from the lowest: compounds 2, 1, 4 and 3 (each within the scatter of the next, the first and the last beyond it).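

In this assay the sulfur can carry a 4-methylcyclohexyl ring directly in place of the 3-(4-methylpiperidin-1-yl)propyl group with no readable change: the step is a 1.2-fold lower number from compound 3 to compound 4 (0.08 log units; within the scatter), even though the ring nitrogen and the chain leading to the ring are gone together. Set against the open chains, the same ring gives a 1.9-fold higher number from compound 1 to compound 4 (0.27 log units; within the scatter) when it replaces pentyl and a 2.2-fold higher number from compound 2 to compound 4 (0.34 log units; beyond the scatter) when it replaces isopentyl, so only the comparison with isopentyl lies beyond the scatter, and that step is modest. Nothing measured here offers an explanation for these results.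

Compound 4 changes two things at once, so the effect of removing the ring nitrogen stays apart from neither the loss of the propyl chain nor the direct attachment of the ring to sulfur; a cyclohexyl ring at the end of the same propyl chain, or a piperidine ring bonded straight to the sulfur, would separate them. Also open, as far as these compounds go, is how this position responds to groups of a different kind, such as a short methyl, an aromatic phenyl ring or a chain ending in a carboxylic acid.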